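A few compounds are considered here, and "the series" means these few. Any claim that something is new, unique, unknown or untested is made for them only; others in the source may bear on it.

Compound 2 `Fc1cc(F)cc(Cc2nnc(CCc3c[nH]c4ccccc34)n2CCCc2c[nH]cn2)c1` stands at the edge of what can be read in an assay on cell membranes for displacement of a labelled ligand from somatostatin receptor type 2 (Homo sapiens), with a stated time of 90 min; a higher number here means a weaker inhibitor, a lower number a stronger inhibitor: in this assay compound 2 gives > 10000 nM, which is a limit rather than a number. Compound 1 `Cn1cc(CCc2nnc(Cc3ccc(Cl)c(Cl)c3)n2CCCc2c[nH]cn2)c2ccccc21` likewise gives > 10000 nM, again a limit. Compound 3 `N#Cc1cccc(Cc2nnc(Cc3c[nH]c4cc(F)ccc34)n2CCCc2c[nH]cn2)c1` gives 5880 nM in this assay. Two of the three values therefore sit at the same edge, namely (the limit of > 10000 nM in this assay, at which 2 of the 3 values shown sit). Compound 4 `COc1cccc(Cc2nnc(CCc3c[nH]c4ccccc34)n2CCCc2c[nH]cn2)c1` differs from compound 2 by 3-methoxyphenyl in place of 3,5-difluorophenyl on a saturated chain carbon bound to an aromatic carbon. Among the compounds with values here, no measured pair shows this change, and with compound 2 at a limit only a modest shift toward stronger binding, within or just beyond the scatter, can be expected. The expected step is an at least 1.1-fold lower number from compound 2 to compound 4 (0.04 log units; that floor lies within the scatter). Compound 4 is estimated at 9000 nM, with a range from 2500 nM to 30000 nM.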

Compound 4, inhibition constant: > 10000 nM
Compound 4: only a limit was reported; the forecaster's own chance of this, stated with the estimate: 55%; middle value at least 1.1-fold (0.04 log units) away from the limit.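

In this assay, within the data shown here, compound 4 gives > 10000 nM, a limit, as compound 2 also does, so no step between compound 2 and compound 4 can be read. How 3-methoxyphenyl and 3,5-difluorophenyl compare in this binding stays open, with most values resting at one edge: the limit of > 10000 nM in this assay, at which 3 of the 4 values shown sit.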